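The compounds below may be only part of what the source reports. "The series", "measured", "known", "first", "only" and "open" are said of these compounds alone.

Three compounds share one core and differ only in the group on an amide-type nitrogen. Compound 1 `COC(=O)c1sccc1NC(=O)CSc1nncnc1-c1ccccc1Cl` carries 2-(methoxycarbonyl)thiophen-3-yl there and gives 105000 nM in an ADME assay on MT4 cells (Homo sapiens) for cytotoxicity, read by MTT assay; a higher number here means that more compound is tolerated, a lower number that less compound is tolerated. Compound 2 `O=C(CSc1nncnc1-c1ccccc1Cl)Nc1ccccn1` carries pyridin-2-yl and gives 172000 nM. Compound 3 `O=C(CSc1nncnc1-c1ccccc1Cl)Nc1ccccc1` carries phenyl and gives 127000 nM. Compound 3 stands second highest of these three numbers; the nearest number is a 1.2-fold higher number from compound 1 to compound 3 (0.08 log units; within the scatter) and the furthest is a 1.4-fold lower number from compound 2 to compound 3 (0.13 log units; within the scatter), so all three sit within the scatter of one another. Compound 4 `O=C(CSc1nncnc1-c1ccccc1Cl)Nc1ccc(Cl)cc1Cl` differs from compound 3 in one place: 2,4-dichlorophenyl in place of phenyl on an amide-type nitrogen. Among the compounds with values here, the steps that bear on this are the earlier exchanges of the aryl group on the same nitrogen: a 1.6-fold higher number from compound 1 to compound 2 (0.21 log units; within the scatter), a 1.2-fold higher number from compound 1 to compound 3 (0.08 log units; within the scatter) and a 1.4-fold lower number from compound 2 to compound 3 (0.13 log units; within the scatter), none of them beyond the scatter. The new exchange is therefore expected to give no step beyond the scatter in this assay, namely a 1.2-fold lower number from compound 3 to compound 4 (0.06 log units; within the scatter). Compound 4 is accordingly estimated at 110000 nM in this assay, within a range of 55000 nM to 220000 nM.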

Compound 4, half-maximal cytotoxic concentration: 51000 nM
Compound 4: middle estimate off by 2.2-fold (0.33 log units), on the high side, and the stated range ends above it.
By their numbers in this assay, from the lowest: compound 4; then compounds 1, 3 and 2 (each within the scatter of the next).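

Placing 2,4-dichlorophenyl on the amide-type nitrogen gives the first steps beyond the scatter at this position in this assay with a 2.5-fold lower number from compound 3 to compound 4 (0.40 log units; beyond the scatter) and a 3.4-fold lower number from compound 2 to compound 4 (0.53 log units; beyond the scatter) and also a 2.1-fold lower number from compound 1 to compound 4 (0.31 log units; beyond the scatter) as the steps. Among these compounds, the number at this position thus moves with the group on that nitrogen, which the phenyl, pyridin-2-yl and 2-(methoxycarbonyl)thiophen-3-yl groups did not show, all three lying within the scatter of one another. No measurement shown here accounts for the lower number. The compounds shown leave open whether a phenyl carrying a single chlorine would give a step of this size or whether both chlorines are needed. They also leave open how a phenyl carrying a methoxy group, an amine or a carboxylic acid would stand in this assay against these four compounds.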